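The source may hold more compounds than are shown below. What is called first, only, known or untested is meant among the compounds shown, and "the series" means these compounds.

Working notes on the series.

Three analogues sharing one core have been measured in a functional assay on MGC-803 cells (Homo sapiens) for antiproliferative activity, read by MTT assay, with a stated time of 72 h; a lower number here means a stronger inhibitor, a higher number a weaker inhibitor. Compound 1 `CCCSc1nc(N/N=C/c2cc(OC)c(OC)c(OC)c2)c2nnn(Cc3ccccc3)c2n1` gives 9410 nM. Compound 2 `CCCSc1nc(N/N=C/c2ccc(N(C)C)cc2)c2nnn(Cc3ccccc3)c2n1`, carrying a different aryl group on the hydrazone, gives 13100 nM, and compound 3 `CCCSc1nc(N/N=C(\C)c2ccc(O)cc2)c2nnn(Cc3ccccc3)c2n1`, with yet another aryl group and a methyl on the hydrazone carbon, gives 16700 nM. The three numbers all lie within the usual scatter of one another, so none stands apart; compound 1 sits at the low end of that narrow range and serves as the starting point for the next step.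

Compound 4 `C#CCSc1nc(N/N=C/c2cc(OC)c(OC)c(OC)c2)c2nnn(Cc3ccccc3)c2n1` has not yet been measured. It differs from compound 1 in one place: ethynyl in place of ethyl on a saturated chain carbon bound to a sulfur. The sulfur-bound chain and the rest of the molecule are otherwise unchanged. Going by the values given here, no measured pair isolates this kind of change, so there is nothing to anchor a direction. For the step from compound 1 to compound 4 in this assay the expectation is a 1.2-fold lower number from compound 1 to compound 4 (0.07 log units; within the scatter), that is, no change beyond the scatter. Compound 4 is therefore estimated at 8000 nM, with a range of 3000 nM to 25000 nM.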

Compound 4, half-maximal inhibitory concentration: 4670 nM
Compound 4: middle estimate off by 1.7-fold (0.23 log units), on the high side; the range from low to high includes it.
By their numbers in this assay, from the lowest: compounds 4, 1, 2 and 3 (each within the scatter of the next, the first and the last beyond it).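

Going by these compounds alone, this is the first pair that isolates a change on the sulfur-bound chain: in this assay the swap of propylsulfanyl for propargylsulfanyl gives a 2.0-fold lower number from compound 1 to compound 4 (0.30 log units; within the scatter) and stays within the scatter, so compound 1 and compound 4 cannot be told apart. At this place, then, a triple bond is carried on the chain without a step beyond the scatter, on this one hydrazone background only. No supporting data on hand bear on this result.

What the compounds shown leave open is whether a butyl chain, an allyl chain or a chain ending in an amine at this place would give a step beyond the scatter. As far as these compounds go, it also remains open whether the propargylsulfanyl group would give a similar step alongside the hydrazone aryl groups of compound 2 and compound 3.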